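The source may report more compounds than this note shows. Statements on the series, on what has been measured and on what is new or still open speak of the compounds shown alone.

Compound 1 `CC(c1ccc2ncc(-c3cnn(C)c3)cc2c1)n1nnc2ncc(-c3ccc(C(N)=O)c(F)c3)nc21` gives 10 uL/min in an ADME assay on microsomes from liver (Rattus norvegicus) for metabolic stability, read by LC-MS, using NADPH, with stated times of 5 min and 30 min, tested at 1 uM; a higher number here means faster removal of the compound, a lower number slower removal.
Compound 2 `CC(c1cc2cc(-c3cnn(C)c3)cnc2cc1F)n1nnc2ncc(-c3ccc(C(N)=O)c(F)c3)nc21` gives 1 uL/min in this assay.
Compound 3 `CC(c1c(F)cc2ncc(-c3cnn(C)c3)cc2c1F)n1nnc2ncc(-c3ccc(C(N)=O)c(F)c3)nc21` gives 12 uL/min in this assay.

Compound 3 stands at the highest of the three numbers, though compound 1 lies within the scatter of it; only compound 2 is set apart beyond the scatter. The two measured steps, a 10-fold lower number from compound 1 to compound 2 (1.00 log units; beyond the scatter) and a 12-fold higher number from compound 2 to compound 3 (1.08 log units; beyond the scatter), each came from a fluoro in place of hydrogen on an aromatic carbon of the shared core, and they ran in opposite directions.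

Compound 4 `CC(c1c(F)cc2ncc(-c3cnn(C)c3)cc2c1F)n1nnc2ncc(-c3ccncc3)nc21` differs from compound 3 in one place: pyridin-4-yl in place of 4-carbamoyl-3-fluorophenyl on an aromatic carbon. The 4-carbamoyl-3-fluorophenyl group that leaves carries one hydrogen-bond donor, which the entering pyridin-4-yl does not.

Neither measured step bears directly on this change: both concern a fluoro on the core, not the aryl ring that sits next to the ring nitrogen. Among the measured compounds shown here, nothing among the measured compounds tests an exchange of that ring. The step from compound 3 to compound 4 is therefore expected to be small, likely within the scatter, with a lean toward a slightly higher number.

Compound 4 is expected to give about 16 uL/min in this assay, with a range from 5 uL/min to 50 uL/min. The expected step is a 1.3-fold higher number from compound 3 to compound 4 (0.12 log units; within the scatter).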

Compound 4, intrinsic clearance in a liver preparation (reported as CLH), per the amount of preparation that the assay uses: 26 uL/min
Compound 4: middle estimate off by 1.6-fold (0.21 log units), on the low side; measured number inside the range.
By their numbers in this assay, from the lowest: compound 2; then compounds 1 and 3 (each within the scatter of the next); then compound 4.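

Among the compounds shown here, this exchange is the first at the aromatic carbon next to the ring nitrogen, since the earlier steps concerned only fluoro on the shared core, and it shows that the number in this assay also responds to the group at this position: pyridin-4-yl in place of 4-carbamoyl-3-fluorophenyl gives a 2.2-fold higher number from compound 3 to compound 4 (0.34 log units; beyond the scatter). The step is modest and smaller than either fluoro step, but it is a single change of several parts, as the entering group has fewer heavy atoms, a ring nitrogen and no hydrogen-bond donor, and it lacks the fluoro and carbamoyl substituents of the leaving group. No measurement is available that explains the higher number for compound 4.

The compounds shown leave open which of those parts carries the step, a question that a plain phenyl or a 4-carbamoylphenyl at this position would help to separate. They also leave open whether the same exchange would give a step of similar size and direction on the core of compound 2, whose number in this assay is much lower.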